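A few compounds are considered here, and "the series" means these few. Any claim that something is new, unique, unknown or untested is made for them only; others in the source may bear on it.

In a functional assay on HL-60 cells (Homo sapiens) for cytotoxicity, read by CellTiter-Blue, with a stated time of 48 h (a lower number here means a stronger inhibitor, a higher number a weaker inhibitor), compound 1 `CCOC(=O)CC1C(C(=O)OCC)=C(N)Oc2ccc(-c3cc(OC)cc(OC)c3)cc21` gives 10700 nM, the lowest of the three numbers recorded so far. Compound 2 `CCOC(=O)CC1C(C(=O)OCC)=C(N)Oc2ccc(-c3ccccn3)cc21` gives 76900 nM, and compound 3 `CCOC(=O)CC1C(C(=O)OCC)=C(N)Oc2ccc(-c3cncnc3)cc21` gives 37900 nM. Each of those two compounds differs from compound 1 only at the group on the aromatic carbon of the shared core: a 7.2-fold higher number from compound 1 to compound 2 (0.86 log units; beyond the scatter), and a 3.5-fold higher number from compound 1 to compound 3 (0.55 log units; beyond the scatter). Between the two azines themselves, a 2.0-fold lower number from compound 2 to compound 3 (0.31 log units; beyond the scatter).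

Compound 4 `CCOC(=O)CC1C(C(=O)OCC)=C(N)Oc2ccc(-c3ccnc(OC)c3)cc21` has not yet been measured in this assay. Compared with compound 1 it carries 2-methoxypyridin-4-yl in place of 3,5-dimethoxyphenyl on an aromatic carbon. The steps from compound 1 to compound 2 and from compound 1 to compound 3 bear on this change; each of them also exchanges the 3,5-dimethoxyphenyl for a six-membered aromatic ring containing nitrogen, and both moved the number upward beyond the scatter. Compound 4 retains a methoxy group, which neither compound 2 nor compound 3 does, so the expected shift is set between the scatter and those two steps. For compound 4 the expected value is 25000 nM, with a range from 10000 nM to 60000 nM. This corresponds to an expected step of a 2.3-fold higher number from compound 1 to compound 4 (0.37 log units; beyond the scatter).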

Compound 4, half-maximal inhibitory concentration: 10200 nM
Estimate against measurement, compound 4: 2.5-fold (0.39 log units) above; the range from low to high includes it.
By their numbers in this assay, from the lowest: compounds 4 and 1 (each within the scatter of the next); then compound 3; then compound 2.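

In this assay, the step of a 1.0-fold lower number from compound 1 to compound 4 (0.02 log units; within the scatter) shows that a six-membered aromatic ring with a nitrogen atom can stand on this aromatic carbon with no change in the number from the all-carbon ring of compound 1. The upward steps seen with compound 2 and compound 3 therefore do not hold for every such ring. The 2-methoxypyridin-4-yl group also separates clearly from the other two groups, with a 3.7-fold lower number from compound 3 to compound 4 (0.57 log units; beyond the scatter) and a 7.5-fold lower number from compound 2 to compound 4 (0.88 log units; beyond the scatter) as its steps. Nothing available accounts for these differences.

The compounds shown leave open whether the methoxy group or the place of the ring nitrogen decides the result, as these two features vary together here. Also open, as far as these compounds go, is how an amine or a carboxylic acid in place of that methoxy group would read in this assay.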